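The source may hold more compounds than are shown below. What is called first, only, known or untested is meant among the compounds shown, and "the series" means these compounds.

Two compounds have been run in a functional assay on HEK293 cells with D(4) dopamine receptor (Homo sapiens) as the target, read by FLIPR; on this read-out lower numbers stand for smaller maximal responses and higher numbers for larger maximal responses. Compound 1 `O/N=C(/CCN1CCN(c2ccccn2)CC1)c1cc(F)cc(F)c1` gives 70%, and compound 2 `CCO/N=C(\CCN1CCN(c2ccccc2)CC1)c1ccccc1` gives 80%. On these two numbers compound 2 stands at the top, yet its nearest neighbour, compound 1, lies within the usual scatter of it, so the pair is not distinguished. Compound 3 `CCO/N=C(\CCN1CCN(c2cccc(OC)c2)CC1)c1ccccc1` is still to be measured. It differs from compound 2 by methoxy in place of hydrogen on an aromatic carbon. Going by the values given here, no pair of measured compounds shows this change, so nothing in the data sets its size. The step of no change at the digits printed from compound 2 to compound 3 (within the scatter) is expected to stay within the scatter. Compound 3 is estimated at 80% in this assay, ranging from 65% to 95%.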

Compound 3, largest response reached (reported as efficacy), in percent of the reference or control that the assay uses: 30%
Compound 3: middle estimate off by 50 percentage points, on the high side, outside the stated range (below it).
By their numbers in this assay, from the lowest: compound 3; then compounds 1 and 2 (each within the scatter of the next).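

In this assay, methoxy in place of hydrogen on an aromatic carbon, meta to a large group, gives a number 50 percentage points lower from compound 2 to compound 3 (beyond the scatter), so this position of the six-membered aromatic ring is not indifferent to substitution. The earlier compounds shown here contained no pair that could show this. Nothing at hand bears on what lies behind the size of this step.

From the compounds shown here alone, whether hydroxy, fluorine or the longer ethoxy would give a similar step stays open. So does whether methoxy on another carbon of that ring would do the same.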